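Moving the phenol: from compound 2 toward compound 3

This account rests on a few compounds, and the source may have more. Where it says the series, first, only, none or still open, it means among the compounds named here.

Measured so far in an assay on cytosol from placenta for inhibition of 17-beta-hydroxysteroid dehydrogenase type 1 (Homo sapiens), read by HPLC, with a stated time of 10 min, in the presence of a further agent that is not named here; on this read-out lower numbers stand for stronger inhibition and higher numbers for weaker inhibition:
compound 1, `Cc1ccccc1N(C)C(=O)c1ccc(-c2cccc(O)c2)o1`, 150 nM
compound 2, `Cc1ccccc1N(C)C(=O)c1ccc(-c2ccccc2O)o1`, 1900 nM

Within the data shown here, compound 2 stands at the higher of the two numbers; the only measured step, a 13-fold higher number from compound 1 to compound 2 (1.10 log units; beyond the scatter), is large. Compound 3, `Cc1ccccc1N(C)C(=O)c1ccc(-c2ccc(O)c(F)c2)o1`, differs from compound 2 by 3-fluoro-4-hydroxyphenyl in place of 2-hydroxyphenyl on an aromatic carbon. Among the measured compounds shown here, no measured compound carries a 3-fluoro-4-hydroxyphenyl, so the single step bears only indirectly: it shows that a 2-hydroxyphenyl sits far weaker than a 3-hydroxyphenyl, and compound 3 also leaves the 2-hydroxyphenyl behind. A gain is therefore expected for compound 3, about a 5.4-fold lower number from compound 2 to compound 3 (0.73 log units; beyond the scatter), giving an estimate of 350 nM with a range from 70 nM to 1800 nM.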

Compound 3, half-maximal inhibitory concentration: 11 nM
For compound 3 the middle estimate is 32-fold (1.50 log units) above the measured one, outside the stated range (below it).
By their numbers in this assay, from the lowest: compound 3; then compound 1; then compound 2.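

In this assay, this aromatic carbon proves able to carry a group far better than either earlier phenol: 3-fluoro-4-hydroxyphenyl gives a 170-fold lower number from compound 2 to compound 3 (2.24 log units; beyond the scatter) and also a 14-fold lower number from compound 1 to compound 3 (1.13 log units; beyond the scatter) in a second comparison. Compound 3 is therefore the strongest of the three, with both of its steps beyond the scatter. No measured information here explains the gain.

On these data alone, the change adds a fluorine and also moves the hydroxyl, so the contribution of each remains open. A plain 4-hydroxyphenyl, or chlorine in place of fluorine, would help separate them.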